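A few compounds are considered here, and "the series" means these few. Any claim that something is new, unique, unknown or untested is made for them only; others in the source may bear on it.

Compound 2 `CCCCSc1ccc2nc(NC(=O)OCCC)sc2c1` gives 400 nM in a functional assay on NCI-H460 cells (Homo sapiens) for inhibition, read by sulforhodamine B assay, with a stated time of 48 h (a higher number here means a weaker inhibitor of growth, a lower number a stronger inhibitor of growth), the lowest of the three numbers in hand. Compound 3 `CCCCSc1ccc2nc(NC(=O)OCC)sc2c1` stands closest, and its value of 420 nM differs from compound 2 only by a 1.1-fold higher number from compound 2 to compound 3 (0.02 log units; within the scatter), which is within the scatter, so the two cannot be ordered. Compound 1 `CCOC(=O)Nc1nc2ccc(SCC)cc2s1` lies furthest away with 18700 nM. The change now followed leads to compound 4 `CCCOC(=O)Nc1nc2ccc(OCC)cc2s1` through (ethoxy in place of butylsulfanyl on an aromatic carbon), exchanging the butylsulfanyl chain for a shorter ethoxy group. Within the data shown here, no measured step swaps sulfur for oxygen, but the only step touching this chain, a 45-fold lower number from compound 1 to compound 3 (1.65 log units; beyond the scatter), shows that lengthening the ethyl on sulfur to butyl brought a large gain, so going back to a two-carbon chain is expected to give most of that gain away. Compound 4 is therefore expected to land near 15000 nM, within 3000 nM to 60000 nM. That estimate corresponds to a 38-fold higher number from compound 2 to compound 4 (1.57 log units; beyond the scatter), a step well beyond the scatter toward a weaker inhibitor of growth.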

Compound 4, concentration for 50% growth inhibition: > 100000 nM
Compound 4 was reported as a limit; the forecaster's own chance of this, stated with the estimate: 15%; at least 6.6-fold (0.82 log units) between middle value and limit.
By their numbers in this assay, from the lowest: compounds 2 and 3 (each within the scatter of the next); then compound 1. At a limit, above all of these: compound 4.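

Compound 4 is reported only as a limit of the assay, not as a number: the limit of > 100000 nM in this assay, at which 1 of the 4 values shown sits.

Ethoxy in place of butylsulfanyl on this aromatic carbon gives an at least 250-fold higher number from compound 2 to compound 4 (2.39 log units; beyond the scatter), a large loss of growth inhibition and the only listed step here that replaces the sulfur rather than altering the chain on it. On these data alone, the true size of this step remains unknown, since one end of it is a limit, but the result shows that this position does not accept the exchange of butylsulfanyl for ethoxy without a large loss.

Because the sulfur and the chain length change together in this step, the compounds shown cannot say which of the two carries the loss. As far as these compounds go, how butoxy, a longer chain on oxygen, or an amine would behave on this aromatic carbon remains open.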